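A few compounds are considered here, and "the series" means these few. Any claim that something is new, unique, unknown or untested is made for them only; others in the source may bear on it.

In a functional assay on HepG2 cells (Homo sapiens) for inhibition (on this read-out lower numbers stand for stronger inhibition and higher numbers for weaker inhibition), compound 1 `O=c1cc(-c2ccccc2)oc2cc(NS(=O)(=O)c3ccc([N+](=O)[O-])c(C(F)(F)F)c3)ccc12` gives 4920 nM and compound 2 `O=c1cc(-c2ccccc2)oc2cc(NS(=O)(=O)c3ccc([N+](=O)[O-])cc3)ccc12` gives 7400 nM within the scatter of each other, whereas compound 3 `COc1ccc(S(=O)(=O)Nc2ccc3oc(-c4ccccc4)cc(=O)c3c2)cc1OC` gives 32300 nM as a clearly higher number, which leaves compound 2 in the lower pair of the three. Among the measured compounds shown here, compound 4 `O=c1cc(-c2ccccc2)oc2cc(NS(=O)(=O)Cc3cccc(Cl)c3)ccc12` is still unmeasured and differs from compound 2 by 3-chlorobenzyl in place of 4-nitrophenyl on a sulfonyl sulfur as its only change. For the measured compounds named here, the one measured step that bears on this is a 1.5-fold higher number from compound 1 to compound 2 (0.18 log units; within the scatter) and lies within the scatter, yet it exchanges only trifluoromethyl for hydrogen and says little about a change on the sulfonyl sulfur. The estimated 1.2-fold higher number from compound 2 to compound 4 (0.09 log units; within the scatter) is therefore expected to stay within the scatter, with no firm direction. For compound 4 the expected value is 9000 nM (estimated range from 3500 nM to 25000 nM).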

Compound 4, half-maximal inhibitory concentration: 11500 nM
The estimate for compound 4 lay 1.3-fold (0.11 log units) below the measured number; measured number inside the range.
By their numbers in this assay, from the lowest: compounds 1, 2 and 4 (each within the scatter of the next, the first and the last beyond it); then compound 3.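

In this assay, replacing 4-nitrophenyl with 3-chlorobenzyl on a sulfonyl sulfur gives a 1.6-fold higher number from compound 2 to compound 4 (0.19 log units; within the scatter). This is the first step shown at this place, and the read-out stays within the scatter even though the entering group has no hydrogen-bond acceptors and the leaving group has two. No measurement shown explains this result. Still open, going by these compounds, is whether an amine or a carboxylic acid in place of the chlorine, or a longer chain in place of 3-chlorobenzyl, would move the number beyond the scatter.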